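The source may hold more compounds than are shown below. What is called first, only, known or untested is meant among the compounds shown, and "the series" means these compounds.

Compound 1 `C=C(C)CCOC(=O)C[C@@H]1C(C(=O)OC)=CO[C@@H](O[C@@H]2O[C@H](COC(C)=O)[C@@H](OC(C)=O)[C@H](OC(C)=O)[C@H]2OC(C)=O)/C1=C/C`: > 15000 nM in a functional assay on SK-BR-3 cells (Homo sapiens) for antiproliferative activity, read by MTT assay, with a stated time of 72 h; on this read-out higher numbers stand for weaker inhibition and lower numbers for stronger inhibition; this is a limit of the assay, not a number.
Compound 2 `C/C=C1/[C@H](O[C@@H]2O[C@H](CO)[C@@H](O)[C@H](O)[C@H]2O)OC=C(C(=O)OC)[C@H]1CC(=O)OCCc1ccc(OC)c(OC)c1`: > 15000 nM in this assay; this too is a limit of the assay, not a number.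

Compound 2 therefore stands where every value shown so far stands, at the limit of > 15000 nM in this assay, at which 2 of the 2 values shown sit. Within the data shown here, nothing measured yet separates compound 2 from compound 1, and no step between measured compounds exists to show how much any structural change moves the read-out of this assay.

Compound 3 `C/C=C1/[C@H](O[C@@H]2O[C@H](CO)[C@@H](O)[C@H](O)[C@H]2O)OC=C(C(=O)OC)[C@H]1CC(=O)OCCc1ccc(F)cc1` has not yet been measured in this assay. It differs from compound 2 in a single place: 4-fluorophenyl in place of 3,4-dimethoxyphenyl on a saturated chain carbon, two bonds along the chain from an oxygen next to a carbonyl group. Among the measured compounds shown here, with both measured values sitting at the same limit, there is no measured step on which to base a direction for this change, and the expected step is a step that the limit leaves unreadable from compound 2 to compound 3, that is, none beyond the usual scatter. Compound 3 is accordingly estimated at 20000 nM, with a range from 7000 nM to 60000 nM, and it is expected that this assay will most likely again report only a limit for compound 3 rather than a number.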

Compound 3, half-maximal inhibitory concentration: > 20000 nM
Compound 3: only a limit was reported (the forecaster's own chance of this, stated with the estimate: 80%); the middle value sits exactly at the limit.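

Compound 2 and compound 3 are both reported in this assay only as limits of the assay, not as numbers, and no step can be read between them. The compounds shown leave open how strongly any of them inhibits, and whether 4-fluorophenyl in place of 3,4-dimethoxyphenyl moves the read-out at all.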